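The compounds below may be only part of what the source reports. "The series", "measured", "known", "first", "only" and "open" are said of these compounds alone.

Measured so far in a functional assay on DU-145 cells (Homo sapiens) for inhibition, read by trypan blue exclusion, with a stated time of 96 h; on this read-out higher numbers stand for weaker inhibition of growth and lower numbers for stronger inhibition of growth:
compound 1 `O=C(/C(=C\c1ccc(I)cc1)Sc1ccc(Br)cc1)c1ccc(Br)cc1` gives 1000 nM
compound 2 `O=C(/C(=C\c1ccc(Br)c(O)c1)S(=O)(=O)c1ccc(Br)cc1)c1ccc(Br)cc1` gives 50000 nM
compound 3 `O=C(/C(=C\c1ccc(F)cc1F)S(=O)(=O)c1ccc(Cl)cc1)c1ccc(Br)cc1` gives 25000 nM

Compound 2 gives the highest number of the three. Compound 3 stands nearest, its number lower by an amount within the scatter, so no order between compound 2 and compound 3 is claimed. Compound 1 lies furthest, with a number lower by an amount beyond the scatter.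

Compound 4 `O=C(/C(=C\c1ccc(F)cc1Cl)S(=O)(=O)c1ccc(Br)cc1)c1ccc(Br)cc1` is not yet measured. It differs from compound 2 in one place: 2-chloro-4-fluorophenyl in place of 4-bromo-3-hydroxyphenyl on a double-bonded chain carbon bound to a double-bonded chain carbon. Within the data shown here, no measured pair shows this change on its own. Compound 3, which also lacks a hydrogen-bond donor on that ring, gives a number close to that of compound 2. The step expected in this assay from compound 2 to compound 4 is therefore small, toward stronger inhibition if anything, and estimated as a 2.0-fold lower number from compound 2 to compound 4 (0.30 log units; within the scatter), within the scatter. For compound 4 the estimated value is 25000 nM, with a range from 8000 nM to 80000 nM.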

Compound 4, concentration for 50% growth inhibition: 50000 nM
Beside the measured number, compound 4's estimate is 2.0-fold (0.30 log units) below it; low and high end bracket the measured number.
By their numbers in this assay, from the lowest: compound 1; then compounds 3, 2 and 4 (each within the scatter of the next).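

In this assay, among these compounds, 2-chloro-4-fluorophenyl in place of 4-bromo-3-hydroxyphenyl on a double-bonded chain carbon bound to a double-bonded chain carbon gives no change at the digits printed from compound 2 to compound 4 (within the scatter) and is the first direct reading of this change on its own. At this place, therefore, the ring hydroxyl and bromine can be exchanged for chlorine and fluorine with no visible shift in the number. No measurement at hand explains this result.

Open, going by these compounds, is whether an amine or a carboxylic acid on this ring, or a longer chain in place of the ring, would give a step beyond the scatter.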